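This account rests on a few compounds, and the source may have more. Where it says the series, first, only, none or still open, it means among the compounds named here.

Compound 2 `CCNC(=S)SCC(=O)c1ccc(OC)cc1` gives the lowest number of the three measured compounds in an assay on HEK293 cells for inhibition of protein deacetylase HDAC6 (Homo sapiens) (on this read-out lower numbers stand for stronger inhibition and higher numbers for weaker inhibition), where compound 2 gives 94 nM. Compound 1 `COc1ccc(C(=O)CSC(=S)SCCNC(C)=O)cc1` gives 1640 nM, and compound 3 `CCOC(=O)SCC(=O)c1ccc(OC)cc1` gives 5360 nM; both steps from compound 2 lie beyond the scatter, so compound 2 is the strongest inhibitor seen so far.

Compound 4 `COCCSC(=S)SCC(=O)c1ccc(OC)cc1` differs from compound 2 in one place: (2-methoxyethyl)sulfanyl in place of ethylamino on a thiocarbonyl carbon. This undoes the kind of change that separates compound 1 from compound 2, where a 17-fold lower number from compound 1 to compound 2 (1.24 log units; beyond the scatter) when an amino group replaced a sulfanyl group on the thiocarbonyl carbon. The step of a 57-fold higher number from compound 2 to compound 3 (1.76 log units; beyond the scatter) also shows that replacing the thioamide part costs much. Compound 4 carries a sulfanyl group again, as compound 1 does, so a large rise in the number is expected for it.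

Because compound 1 gives 1640 nM, compound 4 is expected to land near it, at an estimated 1300 nM in this assay, with a likely range from 400 nM to 4500 nM. This would mean an expected step of a 14-fold higher number from compound 2 to compound 4 (1.14 log units; beyond the scatter).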

Compound 4, half-maximal inhibitory concentration: 2130 nM
The estimate for compound 4 lay 1.6-fold (0.21 log units) below the measured number; the range from low to high includes it.
By their numbers in this assay, from the lowest: compound 2; then compounds 1 and 4 (each within the scatter of the next); then compound 3.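

In this assay, (2-methoxyethyl)sulfanyl in place of ethylamino on the thiocarbonyl carbon costs a great deal (a 23-fold higher number from compound 2 to compound 4 (1.36 log units; beyond the scatter)), so this loss does not depend on the acetamido group carried by compound 1. The end of the sulfanyl chain makes no clear difference here: with methoxy in place of acetamido, the step stays within the scatter (a 1.3-fold higher number from compound 1 to compound 4 (0.11 log units; within the scatter)). No measurement shown here explains why the ethylamino group gives so much lower a number.

From the compounds shown here alone, whether another group on that nitrogen would keep the low number remains open, for example a propylamino or butylamino chain, or a ring such as piperidine. Also open, going by these compounds, is whether a sulfanyl chain ending in a carboxylic acid or a free amine would behave like those in compound 1 and compound 4.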